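Swapping the amide-nitrogen aryl for a methylpyridine

The source may report more compounds than this note shows. Statements on the series, on what has been measured and on what is new or still open speak of the compounds shown alone.

Three compounds built on a shared core, `Cc1ccccc1N(C)C(=O)c1ccc(-c2ccccc2O)o1` for compound 1, `Cc1cccc(F)c1N(C)C(=O)c1ccc(-c2ccc(O)cc2)o1` for compound 2 and `Cc1cc(F)ccc1N(C)C(=O)c1ccc(-c2ccc(O)cc2)o1` for compound 3, have been tested in an assay on cytosol from placenta for inhibition of 17-beta-hydroxysteroid dehydrogenase type 2 (Homo sapiens), read by HPLC, using microsomes, with a stated time of 10 min, in the presence of a further agent that is not named here; on this read-out lower numbers stand for stronger inhibition and higher numbers for weaker inhibition. For compound 1 the read-out is a limit of the assay, > 10000 nM, not a number. In this assay compound 2 gives 3200 nM and compound 3 gives 1700 nM. Compound 3 therefore stands lowest of the two numbers; its nearest neighbour is compound 2, and the step of a 1.9-fold lower number from compound 2 to compound 3 (0.27 log units; within the scatter) lies within the scatter, so the two cannot be told apart.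

Compound 4, `Cc1ncccc1N(C)C(=O)c1ccc(-c2ccc(O)cc2)o1`, has not yet been measured. It differs from compound 3 in one place: 2-methylpyridin-3-yl in place of 4-fluoro-2-methylphenyl on an amide-type nitrogen. Among the measured compounds shown here, the only measured step on the amide nitrogen's aryl group, a 1.9-fold lower number from compound 2 to compound 3 (0.27 log units; within the scatter), exchanged one fluorine-and-methyl pattern for another and moved the number by no more than the scatter. For the measured compounds named here, no measured step replaces the carbon ring by a pyridine, so there is no direct guide for the added acceptor nitrogen. On the evidence of compound 3 and its step from compound 2, the expectation for compound 4 is a step of a 1.5-fold higher number from compound 3 to compound 4 (0.17 log units; within the scatter), that is, no change beyond the scatter. Compound 4 is therefore estimated at 2500 nM in this assay, with a likely range from 800 nM to 8000 nM.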

Compound 4, half-maximal inhibitory concentration: > 30000 nM
Compound 4: only a limit was reported; the forecaster's own chance of this, stated with the estimate: 15%; middle value at least 12-fold (1.07 log units) from the limit.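

In this assay the result for compound 4 is a limit of the assay and not a number: the limit of > 30000 nM in this assay, at which 1 of the 4 values shown sits.

Even so, the change to 2-methylpyridin-3-yl on the amide-type nitrogen can be read against both fluorine-bearing compounds, giving an at least 17-fold higher number from compound 3 to compound 4 (1.24 log units; beyond the scatter) and an at least 9.3-fold higher number from compound 2 to compound 4 (0.97 log units; beyond the scatter), whereas the exchange of one fluorine-and-methyl pattern for another gave only a 1.9-fold lower number from compound 2 to compound 3 (0.27 log units; within the scatter). Among the compounds that differ in one place, this aryl group therefore stands out as a position where the change from a carbon-only ring to a ring with a nitrogen, with the fluorine gone, weakens inhibition beyond the scatter.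

This single exchange removes the fluorine and adds the ring nitrogen together, so the compounds shown cannot separate the two changes or give a reason for the loss. Also open, on these data alone, is whether a fluoropyridine ring, or an amine or methoxy group on the pyridine, would bring the number back towards that of compound 3.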